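Diethylaminopropyl chain applied to the 2,4-difluoro analogue

The compounds below may be only part of what the source reports. "The series", "measured", "known", "first", "only" and "open" are said of these compounds alone.

For the measured compounds named here, in a functional assay on HT-29 cells (Homo sapiens) for inhibition, read by MTT assay, with a stated time of 72 h (a lower number here means a stronger inhibitor, a higher number a weaker inhibitor), compound 3 `CN(C)CCn1c(=O)c(=Cc2ccc(F)cc2F)s/c1=C1\C(=O)Nc2cc(F)ccc21` stands second highest of the three numbers measured so far, giving 6460 nM. Its nearest neighbour is compound 1 `CN(C)CCn1c(=O)c(=Cc2ccc(F)c(F)c2)s/c1=C1\C(=O)Nc2cc(F)ccc21`, which gives 12100 nM; the step between them is a 1.9-fold lower number from compound 1 to compound 3 (0.27 log units; within the scatter), so the two are indistinguishable here. Furthest away is compound 2 `CCN(CC)CCCn1c(=O)c(=Cc2ccc(F)c(F)c2)s/c1=C1\C(=O)Nc2cc(F)ccc21`, which gives 28 nM.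

Compound 4 `CCN(CC)CCCn1c(=O)c(=Cc2ccc(F)cc2F)s/c1=C1\C(=O)Nc2cc(F)ccc21` differs from compound 3 in one place: (diethylamino)methyl in place of dimethylamino on a saturated chain carbon, two bonds along the chain from an aromatic nitrogen. Going by the values given here, the only measured step that bears on this change is the one from the dimethylamino to the diethylamino chain on the 3,4-difluoro pair, which read a 430-fold lower number from compound 1 to compound 2 (2.64 log units; beyond the scatter), far beyond the scatter. Since the 2,4-difluoro and 3,4-difluoro pair gave a step within the scatter, the chain change is expected to carry over with comparable size, and a drop of roughly a 430-fold lower number from compound 3 to compound 4 (2.63 log units; beyond the scatter) is expected. Compound 4 is therefore estimated at 15 nM in this assay, with a range of 5 nM to 60 nM.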

Compound 4, half-maximal inhibitory concentration: 1520 nM
The estimate for compound 4 lay 100-fold (2.01 log units) below the measured number; measured number above the stated range.
By their numbers in this assay, from the lowest: compound 2; then compound 4; then compounds 3 and 1 (each within the scatter of the next).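

In this assay the swap of 2-(dimethylamino)ethyl for 3-(diethylamino)propyl has no fixed size across the two difluorophenyl partners, giving only a 4.3-fold lower number from compound 3 to compound 4 (0.63 log units; beyond the scatter) on the 2,4-difluorophenyl side: the same change on two cores in this assay, a 430-fold lower number (2.64 log units; beyond the scatter) from compound 1 to compound 2 and a 4.3-fold lower number (0.63 log units; beyond the scatter) from compound 3 to compound 4, 100-fold (2.01 log units) apart, beyond the scatter of two such steps.
The difluorophenyl swap, within the scatter on the 2-(dimethylamino)ethyl chain, becomes a 54-fold higher number from compound 2 to compound 4 (1.73 log units; beyond the scatter) on the 3-(diethylamino)propyl chain: the same change on two cores in this assay, a 1.9-fold lower number (0.27 log units; within the scatter) from compound 1 to compound 3 and a 54-fold higher number (1.73 log units; beyond the scatter) from compound 2 to compound 4, 100-fold (2.01 log units) apart, beyond the scatter of two such steps.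
The two changes are therefore not additive in these four compounds, and the large gain seen in compound 2 belongs to the chain and the 3,4-difluorophenyl group together, not to the chain alone.

The swap alters chain length and the amine substituents at once, so the shown compounds cannot separate the two. A 3-(dimethylamino)propyl or 2-(diethylamino)ethyl chain on either difluorophenyl partner would divide the step.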